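Removing (2-hydroxyethyl)amino from compound 2

The source may report more compounds than this note shows. Statements on the series, on what has been measured and on what is new or still open speak of the compounds shown alone.

In a functional assay on SNU-638 cells (Homo sapiens) for inhibition, read by sulforhodamine B assay, with a stated time of 2 days (a higher number here means a weaker inhibitor of growth, a lower number a stronger inhibitor of growth), compound 1 (`Cc1c(C#N)c(NCCO)nc2nc(NCCO)nc(N)c12`) gives 18200 nM, compound 2 (`N#Cc1cc2c(N)nc(NCCO)nc2nc1NCCO`) gives 7950 nM and compound 3 (`Cc1c(C#N)c(Nc2ccc(S(N)(=O)=O)cc2)nc2ncnc(N)c12`) gives 6200 nM. Compound 2 thus lies within the scatter of compound 3 and clearly under compound 1. The next step leads to compound 4 (`N#Cc1cc2c(N)ncnc2nc1NCCO`), with the change hydrogen in place of (2-hydroxyethyl)amino on an aromatic carbon, between two ring nitrogen atoms.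

Among the compounds with values here, the only measured step, a 2.3-fold lower number from compound 1 to compound 2 (0.36 log units; beyond the scatter), is a different change, hydrogen in place of methyl, and it says little about this one. Within the data shown here, no measured pair isolates the loss of (2-hydroxyethyl)amino. Compound 3, at 6200 nM, also carries hydrogen at that place, but it differs from compound 4 in its other substituents, so it serves only as a rough anchor. Going by these compounds, with compound 2 and compound 3 so close, no step beyond the scatter is expected, and the direction remains open. The expected step is a 1.1-fold higher number from compound 2 to compound 4 (0.05 log units; within the scatter). For compound 4 the estimated value is 9000 nM, with an expected range from 3000 nM to 30000 nM.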

Compound 4, concentration for 50% growth inhibition: 20800 nM
Compound 4: the middle estimate sits 2.3-fold (0.36 log units) below what was measured, within the range that was stated.
By their numbers in this assay, from the lowest: compounds 3 and 2 (each within the scatter of the next); then compounds 1 and 4 (each within the scatter of the next).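

In this assay the aromatic carbon between two ring nitrogen atoms now has its first direct reading: hydrogen in place of (2-hydroxyethyl)amino there gives a 2.6-fold higher number from compound 2 to compound 4 (0.42 log units; beyond the scatter) and is a modest step beyond the scatter. Compound 2 and compound 4 differ in this one place, so the step shows that growth inhibition on this core responds to the group at this position, which the earlier step could not show, as it concerned hydrogen in place of methyl at a different place. The step shows only that the number changes with the loss of the group, and no measurement shown here offers an explanation for it.

Still open, going by these compounds, is which part of the (2-hydroxyethyl)amino group carries the step, a question that a simple methylamino group, a dimethylamino group or a longer hydroxyalkylamino chain at this position would address. Also open, on these data alone, is whether the step keeps its size with the methyl group of compound 1 on the core, and what the remaining (2-hydroxyethyl)amino group of compound 4 contributes.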